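The compounds below may be only part of what the source reports. "The series", "measured", "known", "first", "only" and "open" are said of these compounds alone.

Values measured in an ADME assay on A549 cells (Homo sapiens) for cytotoxicity, read by CellTiter-Glo; on this read-out lower numbers stand for higher toxicity in this test and higher numbers for lower toxicity in this test:
Compound 1 (`Cc1c(Cc2ccccc2)c(=O)oc2cc(OCC(O)CNCC3CC3)ccc12`) gives > 100000 nM
Compound 2 (`Cc1c(Cc2ccccc2)c(=O)oc2cc(OCC(O)CNc3cc([N+](=O)[O-])ccc3O)ccc12`) gives > 100000 nM

Compound 2 stands at > 100000 nM, which is a limit of the assay and not a number. That is the limit of > 100000 nM in this assay, at which 2 of the 2 values shown sit, and compound 1 shares it. Compound 3 (`Cc1c(Cc2ccccc2)c(=O)oc2cc(OCC(O)CNCc3ccccc3)ccc12`) differs from compound 2 by benzyl in place of 2-hydroxy-5-nitrophenyl on an amine nitrogen, with benzyl taking the place of 2-hydroxy-5-nitrophenyl on an amine nitrogen. Within the data shown here, the only measured step bearing on this is a step that the two limits leave unreadable from compound 1 to compound 2, a change on the same nitrogen, so it gives no size to carry over. No change beyond the scatter is therefore expected in this assay, and no direction can be given. The expected outcome is a number no higher from compound 2 to compound 3 (the limit leaves the size open) as an estimate. For compound 3 the estimated value is 100000 nM, with an expected range of 40000 nM to 200000 nM.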

Compound 3, half-maximal cytotoxic concentration: > 100000 nM
Compound 3: no number, only a limit (the forecaster's own chance of this, stated with the estimate: 75%); the middle value sits exactly at the limit.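

Among these compounds, no step among compound 1, compound 2 and compound 3 can be read in this assay, since each value is a limit and not a number: the limit of > 100000 nM in this assay, at which 3 of the 3 values shown sit. The compounds shown leave open whether the group on the amine nitrogen changes the read-out at all.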